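Fluorinated aryl variants on the phenethyl chain

The source may hold more compounds than are shown below. What is called first, only, known or untested is meant among the compounds shown, and "the series" means these compounds.

Compound 1 `CCc1nc(Cl)c2n1CCN([C@@H](C(=O)NC)c1ccccc1)[C@H]2CCc1cccc(C(F)(F)F)c1` carries a 3-(trifluoromethyl)phenyl on a saturated chain carbon, two bonds along the chain from a saturated ring carbon. In a functional assay on CHO cells for antagonist activity at Orexin receptor type 2 (Homo sapiens), read by FLIPR and calcium flux (a higher number here means a weaker inhibitor, a lower number a stronger inhibitor), compound 1 gives 10 nM. Compound 2 `CCc1nc(Cl)c2n1CCN([C@@H](C(=O)NC)c1ccccc1)[C@H]2CCc1ccc(C(F)(F)F)cc1F`, with 2-fluoro-4-(trifluoromethyl)phenyl there instead, gives 12 nM, and the step of a 1.2-fold higher number from compound 1 to compound 2 (0.08 log units; within the scatter) stays within the scatter, so compound 1 and compound 2 cannot be ranked against each other. Compound 3 `CCc1nc(Cl)c2n1CCN([C@@H](C(=O)NC)c1ccccc1)[C@H]2CCc1cc(F)c(C(F)(F)F)cc1F` has not been measured; it differs from compound 1 by 2,5-difluoro-4-(trifluoromethyl)phenyl in place of 3-(trifluoromethyl)phenyl on a saturated chain carbon, two bonds along the chain from a saturated ring carbon. For the measured compounds named here, the one step that bears on this is the move from compound 1 to compound 2, which swapped the same aryl group for a fluorinated partner and left the number essentially unchanged; the aryl group of compound 3 itself is covered by no measured pair. The step expected is therefore a 1.4-fold higher number from compound 1 to compound 3 (0.15 log units; within the scatter), nothing beyond the scatter. Compound 3 is estimated at 14 nM, within a range from 5 nM to 40 nM.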

Compound 3, half-maximal inhibitory concentration: 17 nM
Beside the measured number, compound 3's estimate is 1.2-fold (0.08 log units) below it; the measured number falls inside the stated range.
By their numbers in this assay, from the lowest: compounds 1, 2 and 3 (each within the scatter of the next).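

In this assay, the 2,5-difluoro-4-(trifluoromethyl)phenyl on a saturated chain carbon can be carried without a clear loss against the 3-(trifluoromethyl)phenyl, with a 1.7-fold higher number from compound 1 to compound 3 (0.23 log units; within the scatter) as the step. The new pair also isolates fluoro in place of hydrogen on an aromatic carbon, and a 1.4-fold higher number from compound 2 to compound 3 (0.15 log units; within the scatter) means that this added fluoro does not separate the two compounds. Nothing measured here accounts for these numbers.

Going by these compounds, it remains open whether the numbers in this assay would hold with a nitrile or a methoxy group in place of the trifluoromethyl, or with a pyridine ring in place of the phenyl. The compounds shown also leave open what a longer chain at this position would give.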